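A few compounds are considered here, and "the series" means these few. Any claim that something is new, unique, unknown or untested is made for them only; others in the source may bear on it.

Notes on the series in a functional assay on HeLa cells (Homo sapiens) for inhibition, read by MTT assay, with a stated time of 72 h (a lower number here means a stronger inhibitor, a higher number a weaker inhibitor), follow. Among the compounds with values here, compound 1 `COc1ccc(C(=O)/C=C/c2cc(OC)c(OC)cc2OC)cc1` gives 37600 nM as the only true number so far. Compound 2 `COc1cc(OC)c(OC)cc1/C=C/C(=O)c1ccc(-c2c[nH]cn2)cc1` gives > 150000 nM, which is a limit of the assay. Compound 3 `COc1cc(OC)c(OC)cc1/C=C/C(=O)c1cc(Cl)ccc1O` gives > 150000 nM, also a limit and not a number. Compound 4 `COc1cc(OC)c(OC)cc1/C=C/C(=O)c1ccc(F)cc1` departs from compound 3 through 4-fluorophenyl in place of 5-chloro-2-hydroxyphenyl on a carbonyl carbon on the carbonyl carbon. The closest guide is an at least 3.9-fold higher number from compound 1 to compound 3 (0.60 log units; beyond the scatter) at that same carbonyl carbon. Less direct is an at least 3.9-fold higher number from compound 1 to compound 2 (0.60 log units; beyond the scatter) on an aromatic carbon. Both are at least modest, so a lower number is expected here, with the estimate being an at least 3.0-fold lower number from compound 3 to compound 4 (0.47 log units; beyond the scatter) in this assay overall. The estimate for compound 4 is 50000 nM, with an expected range from 15000 nM to 150000 nM for now.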

Compound 4, half-maximal inhibitory concentration: 28600 nM
Compound 4: middle estimate off by 1.7-fold (0.24 log units), on the high side; low and high end bracket the measured number.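

At the carbonyl carbon, 4-fluorophenyl gives a true number in this assay where 5-chloro-2-hydroxyphenyl gave only a limit, with an at least 5.2-fold lower number from compound 3 to compound 4 (0.71 log units; beyond the scatter); fluoro in place of 1H-imidazol-4-yl on an aromatic carbon gives an at least 5.2-fold lower number from compound 2 to compound 4 (0.71 log units; beyond the scatter). Fluoro in place of methoxy on an aromatic carbon gives a 1.3-fold lower number from compound 1 to compound 4 (0.12 log units; within the scatter), so the two cannot be told apart here. The two larger steps start from a limit, so their full size stays unknown: the limit of > 150000 nM in this assay, at which 2 of the 4 values shown sit.

Open, from the compounds shown here alone, is whether an amine or a carboxylic acid on that aromatic carbon would give a true number. Also open, going by these compounds, is whether the chloro or the hydroxy group of 5-chloro-2-hydroxyphenyl accounts for the limit of compound 3.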